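Dichloroacetamide series: iodo in place of chloro

The source may report more compounds than this note shows. Statements on the series, on what has been measured and on what is new or still open speak of the compounds shown alone.

Measured so far in a functional assay on A549 cells (Homo sapiens) for antiproliferative activity, read by MTT assay, with a stated time of 72 h; a lower number here means a stronger inhibitor, a higher number a weaker inhibitor:
- compound 1 `O=C(Nc1ccccc1[N+](=O)[O-])C(Cl)Cl` gives 198000 nM
- compound 2 `Cc1cccc(NC(=O)C(Cl)Cl)c1` gives 41100 nM
- compound 3 `O=C(Nc1cccc(Cl)c1)C(Cl)Cl` gives 14800 nM

Compound 3 stands at the lowest number of the three. Its nearest neighbour is compound 2, and the step of a 2.8-fold lower number from compound 2 to compound 3 (0.44 log units; beyond the scatter) is beyond the scatter; compound 1 lies much further up, with a number well above that of compound 3. For the measured compounds named here, only one single-point change is on record, the one from compound 2 to compound 3, and it shows that a chloro in place of a methyl on the ring carbon gives a modest gain.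

Compound 4 `O=C(Nc1cccc(I)c1)C(Cl)Cl` differs from compound 3 by iodo in place of chloro on an aromatic carbon. Going by the values given here, no measured step in this assay covers a swap of one halogen for another, so the expectation rests on the general picture: the shared core with a single substituent on the ring sits in the low-micromolar-to-tens-of-micromolar region, and the only recorded substituent change moved the number by a modest amount. An iodo for a chloro is a smaller structural move than chloro for methyl or than the change to the nitro group of compound 1, so the step of a 1.5-fold lower number from compound 3 to compound 4 (0.17 log units; within the scatter) is expected to be small, most likely within or close to the scatter, with a slight lean toward a lower number. Compound 4 is therefore estimated at 10000 nM, with a range from 4000 nM to 30000 nM.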

Compound 4, half-maximal inhibitory concentration: 4760 nM
Estimate against measurement, compound 4: 2.1-fold (0.32 log units) above; low and high end bracket the measured number.
By their numbers in this assay, from the lowest: compound 4; then compound 3; then compound 2; then compound 1.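

In this assay, the aromatic carbon carrying the halogen responds to an exchange of one halogen for another, not only to chloro in place of methyl: iodo in place of chloro gives a 3.1-fold lower number from compound 3 to compound 4 (0.49 log units; beyond the scatter). Measured against the methyl end of the set, the same position gives an 8.6-fold lower number from compound 2 to compound 4 (0.94 log units; beyond the scatter), so across compounds 2, 3 and 4 the number falls in the order methyl, chloro, iodo, a pattern that rests on these three compounds alone and that compound 1, with its nitro group elsewhere on the ring, can neither support nor contradict. No measurement at hand bears on what underlies this order.

From the compounds shown here alone, whether a fluoro or bromo group on this same aromatic carbon would fit the order, and whether a methoxy group, an amine or a carboxylic acid there would keep the number low, remains open. Also open, going by these compounds, is whether iodo on a different ring carbon would give a similar number, and whether the gain would hold with the dichloroacetamide side replaced by a monochloroacetamide or a longer acyl chain.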